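A few compounds are considered here, and "the series" means these few. Any claim that something is new, unique, unknown or untested is made for them only; others in the source may bear on it.

Three compounds were tested in a functional assay on the whole organism (strain albino) for inhibition, with Rattus norvegicus as the target, read by paw edema, with stated times of 30 min and 1 h, at a dose of 100 mg/kg by the oral route; on this read-out higher numbers stand for more inhibition at the one dose given (going by the name of the read-out) and lower numbers for less inhibition. Compound 1 `COc1ccc(C2=NNC(c3ccco3)C2)cc1OC` gives 45%, compound 2 `COc1ccc(C2=NNC(c3c(Cl)cccc3Cl)C2)cc1OC` gives 26%, and compound 3 `COc1ccc(C2CC(c3ccc(OC)c(OC)c3)=NN2C(=O)CBr)c(OC)c1` gives 53%. Compound 3 carries the highest of the three numbers; the gap to compound 1 lies within the usual scatter, while the gap to compound 2 lies beyond it. Compound 4 `COc1ccc(C2CC(c3ccc(OC)c(OC)c3)=NN2C(=O)CO[N+](=O)[O-])c(OC)c1` differs from compound 3 in a single place: nitrooxy in place of bromo on a saturated chain carbon bound to a carbonyl carbon. Within the data shown here, no measured pair shows this change, so its effect in this assay is unknown; a step of modest size in either direction, or none beyond the scatter, is expected. For compound 4 the estimated value in this assay is 50%, with a range from 35% to 65%. That estimate amounts to an expected step of a number 3 percentage points lower from compound 3 to compound 4 (within the scatter).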

Compound 4, a percentage reported as inhibition, in the whole organism at one dose (the size of the read-out at that dose, not a potency): 38%
Beside the measured number, compound 4's estimate is 12 percentage points above it; low and high end bracket the measured number.
By their numbers in this assay, from the lowest: compound 2; then compounds 4, 1 and 3 (each within the scatter of the next, the first and the last beyond it).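

At the saturated chain carbon bound to a carbonyl carbon, the group matters in this assay: nitrooxy in place of bromo gives a number 15 percentage points lower from compound 3 to compound 4 (beyond the scatter). Among these compounds, this is the first change in one place in this set, and it shows that this position responds to what it carries, with bromo ahead of nitrooxy. Nothing available explains the drop.

Among the compounds shown here, with only two groups compared at this carbon, it remains open how others would behave. An amine, a carboxylic acid or a longer chain ending in nitrooxy could show whether the loss is specific to nitrooxy.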